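Replacing an allyl with a 4-fluorobenzyl: cytotoxicity outlook

This account rests on a few compounds, and the source may have more. Where it says the series, first, only, none or still open, it means among the compounds named here.

Compound 1, `C=CCN1C(=O)N(Cc2ccccc2)S(=O)(=O)n2cccc21`: > 802000 nM
Compound 2, `N#CCN1C(=O)N(Cc2ccccc2)S(=O)(=O)c2cscc21`: 503000 nM
Compound 3, `N#Cc1ccccc1CN1C(=O)N(Cc2cccc(Cl)c2)S(=O)(=O)n2cccc21`: > 293000 nM

All three compounds were tested in an ADME assay on MT4 cells (Homo sapiens) for cytotoxicity, read by MTT assay, with a stated time of 5 days; a higher number here means that more compound is tolerated, a lower number that less compound is tolerated. Compound 1 gives > 802000 nM, which is a limit of the assay and not a number; it sits at the limit of > 802000 nM in this assay, at which 1 of the 3 values shown sits. Compound 3 likewise gives only a limit, > 293000 nM, at the limit of > 293000 nM in this assay, at which 1 of the 3 values shown sits. Compound 2 gives a number, 503000 nM. Taken together, these values show compounds that the cells tolerate up to very high concentrations, with compound 1 standing at the higher of the two limits.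

Compound 4, `O=C1N(Cc2ccc(F)cc2)c2cccn2S(=O)(=O)N1Cc1ccccc1`, has not been measured. It differs from compound 1 in one place: 4-fluorophenyl in place of vinyl on a saturated chain carbon bound to an amide-type nitrogen in a ring. Within the data shown here, no measured pair differs in just this way, so the size of the step cannot be read off directly. Since compound 2 gives 503000 nM while carrying a different substituent, a substituent change of this kind appears to leave tolerance high. The step of an at least 1.7-fold lower number from compound 1 to compound 4 (0.25 log units; that floor lies within the scatter) is therefore expected to be small, perhaps a modest loss, not clearly beyond the scatter. Compound 4 is estimated at 450000 nM, with a range from 150000 nM to 1200000 nM.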

Compound 4, half-maximal cytotoxic concentration: 150000 nM
Compound 4: the middle estimate sits 3.0-fold (0.48 log units) above what was measured; measured number inside the range.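

In this assay, the cells turn out to be sensitive to what sits at this place, on a saturated chain carbon bound to an amide-type nitrogen in a ring: an at least 5.3-fold lower number from compound 1 to compound 4 (0.72 log units; beyond the scatter). Among these compounds, this is the first comparison here between two compounds that differ in only one place, and it shows that exchanging the small vinyl for the larger 4-fluorophenyl makes the compound less well tolerated. Compound 1 gives only a limit of the assay and not a number, so this step is a floor and its full size stays unknown: the limit of > 802000 nM in this assay, at which 1 of the 4 values shown sits.

The compounds shown cannot tell whether the added aromatic ring or its fluorine accounts for the loss, and a plain phenyl in that place would separate the two. On these data alone, it also remains open how a chain ending in an amine or a carboxylic acid would fare here.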